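The source may report more compounds than this note shows. Statements on the series, on what has been measured and on what is new or still open speak of the compounds shown alone.

Measured compounds in a functional assay on MDA-MB-231 cells (Homo sapiens) for antiproliferative activity, read by MTT assay, with a stated time of 72 h; on this read-out lower numbers stand for stronger inhibition and higher numbers for weaker inhibition:
- compound 1 `NS(=O)(=O)c1ccc(S(=O)(=O)Nc2cccc(-c3nc(-c4ccc(NC(=O)c5cccnc5)cc4Cl)no3)c2)cc1` gives > 10000 nM, a limit of the assay and not a number.
- compound 2 `CC(=O)Nc1ccc(S(=O)(=O)Nc2cccc(-c3nc(-c4ccc(NC(=O)c5cccnc5)c(C(F)(F)F)c4)no3)c2)cc1` gives > 10000 nM, again a limit.
- compound 3 `O=C(Nc1ccc(Cl)cc1)Nc1cccc(-c2nc(-c3ccc(NC(=O)c4cccnc4)cc3Cl)no2)c1` gives > 10000 nM, again a limit.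

Compound 3 thus stands at the same limit as the other two: the limit of > 10000 nM in this assay, at which 3 of the 3 values shown sit. No measured step between any two of these compounds is available, so nothing in the numbers separates compound 3 from compound 1 or compound 2; each shows only the limit.

Compound 4 `CC(=O)Nc1ccc(NC(=O)Nc2cccc(-c3nc(-c4ccc(NC(=O)c5cccnc5)cc4Cl)no3)c2)cc1Br` is the next compound. It differs from compound 3 by 4-acetamido-3-bromophenyl in place of 4-chlorophenyl on an amide-type nitrogen. The change is small in the counted atoms and sits on the urea side of the shared core, away from the pyridine amide.

With every measured value sitting at the limit, no direction can be read from the series. The expected step of a number no higher from compound 3 to compound 4 (the limit leaves the size open) is none beyond the scatter, and compound 4 is most likely to return only a limit again. Compound 4 is expected at about 10000 nM, with a range of 3000 nM to 30000 nM.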

Compound 4, half-maximal inhibitory concentration: 1000 nM
Compound 4: middle estimate off by 10-fold (1.00 log units), on the high side; measured number below the stated range.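

In this assay, among the compounds shown here, the side of the shared core carrying the amide-type nitrogen is the first place in this set to give a response that can be read, with 4-acetamido-3-bromophenyl in place of 4-chlorophenyl giving an at least 10-fold lower number from compound 3 to compound 4 (1.00 log units; beyond the scatter). Going by these compounds, compound 3 gives > 10000 nM, which is a limit and not a number, so the full size of this step stays unknown. Compound 4 is the only compound here with a value that is a number and not a limit: the limit of > 10000 nM in this assay, at which 3 of the 4 values shown sit.

On these data alone, the acetamido group and the bromine enter together, so it remains open which of them carries the step, and 4-acetamidophenyl or 3-bromophenyl on the same nitrogen would separate the two. Also open, as far as these compounds go, is whether a free amine in place of the acetamido group, or chlorine in place of the bromine, keeps the value of compound 4 at 1000 nM.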